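Isopropyl for 2-Methoxyethyl on the Aromatic Nitrogen

The compounds below may be only part of what the source reports. "The series", "measured", "known", "first", "only" and "open" are said of these compounds alone.

Compound 1 `COc1ccc(NC(=O)C(=O)c2cn(C(C)C)c3ccccc23)cn1` gives 85 nM.
Compound 2 `COCCn1cc(C(=O)C(=O)Nc2ccc(OC(F)(F)F)cc2)c2ccccc21` gives 487 nM.
Compound 3 `COc1ccc(NC(=O)C(=O)c2cn(C(C)C)c3cccnc23)cn1` gives only a limit, > 10000 nM.

In a functional assay on FaDu cells (Homo sapiens) for cytotoxicity, read by MTT assay, with a stated time of 72 h (a higher number here means that more compound is tolerated, a lower number that less compound is tolerated), compound 2 stands at the highest of the two numbers shown; its nearest neighbour is compound 1, whose number is lower by a gap beyond the usual scatter. For compound 3 the assay reports a limit rather than a number, (the limit of > 10000 nM in this assay, at which 1 of the 3 values shown sits). The unmeasured compound 4 `CC(C)n1cc(C(=O)C(=O)Nc2ccc(OC(F)(F)F)cc2)c2ccccc21` differs from compound 2 in one place: isopropyl in place of 2-methoxyethyl on an aromatic nitrogen. For the measured compounds named here, no step between measured compounds covers this change alone. Compound 1 carries the same isopropyl group and gives a lower number, but its amide part also differs, so that comparison is not clean. Compound 4 is expected to sit lower than compound 2, an estimated step of a 3.2-fold lower number from compound 2 to compound 4 (0.51 log units; beyond the scatter). The expected value for compound 4 is 150 nM, within 40 nM to 600 nM.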

Compound 4, concentration lethal to 50% of the cells: 8930 nM
Compound 4: middle estimate off by 60-fold (1.77 log units), on the low side; measured number outside the range, above it.
By their numbers in this assay, from the lowest: compound 1; then compound 2; then compound 4. At a limit, above all of these: compound 3.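

In this assay, isopropyl in place of 2-methoxyethyl on the aromatic nitrogen gives an 18-fold higher number from compound 2 to compound 4 (1.26 log units; beyond the scatter), so this position is far more sensitive to the change than compound 1 suggested. Isopropyl does not set the number alone: with a different amide part, compound 1 gives 85 nM, while compound 4 gives 8930 nM. Compound 3 gives only a limit, not a number: the limit of > 10000 nM in this assay, at which 1 of the 4 values shown sits.

As far as these compounds go, whether a plain butyl chain or a 2-aminoethyl group would behave like 2-methoxyethyl remains open. So does the effect of 2-methoxyethyl on the amide part of compound 1.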